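The compounds below may be only part of what the source reports. "The series", "measured", "known", "first", "only" and "open" are said of these compounds alone.

Measured so far:
compound 1 `COc1cc(C(=O)c2sc(-c3ccc(Cl)cc3)cc2N)cc(OC)c1OC` — 70 nM
compound 2 `COc1cc(C(=O)c2sc(-c3ccccc3Cl)cc2N)cc(OC)c1OC` — 16 nM

In a functional assay on CCRF-CEM cells (Homo sapiens) for antiproliferative activity (a lower number here means a stronger inhibitor, a higher number a weaker inhibitor), compound 2 gives the lowest of the two numbers; its nearest neighbour is compound 1, which gives 70 nM. For the measured compounds named here, the one step recorded so far, a 4.4-fold lower number from compound 1 to compound 2 (0.64 log units; beyond the scatter), moves the chlorine within the phenyl ring and is modest in size. Compound 3 `COc1cc(C(=O)c2sc(-c3cccs3)cc2N)cc(OC)c1OC` is not yet measured. It differs from compound 2 in one place: thiophen-2-yl in place of 2-chlorophenyl on an aromatic carbon. Going by the values given here, no measured step swaps the ring itself, so the step from compound 1 to compound 2 bears on this change only loosely, as a sign that alterations at this position shift this assay by a modest amount. Compound 3 is therefore expected to show a modest step, most likely towards a higher number, a 2.5-fold higher number from compound 2 to compound 3 (0.40 log units; beyond the scatter), with a wide range. The estimate for compound 3 is 40 nM, expected to fall between 10 nM and 160 nM.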

Compound 3, half-maximal inhibitory concentration: 9.4 nM
The estimate for compound 3 lay 4.3-fold (0.63 log units) above the measured number, and the stated range ends above it.
By their numbers in this assay, from the lowest: compounds 3 and 2 (each within the scatter of the next); then compound 1.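

The result shows that a chlorine-bearing six-membered ring is not needed on this aromatic carbon next to the ring sulfur: in this assay, the smaller thiophen-2-yl ring cannot be told apart from 2-chlorophenyl (a 1.7-fold lower number from compound 2 to compound 3 (0.23 log units; within the scatter)). Thiophen-2-yl also clearly outdoes 4-chlorophenyl (a 7.4-fold lower number from compound 1 to compound 3 (0.87 log units; beyond the scatter)), so among these three compounds only the 4-chlorophenyl group stands apart, with the higher number. No evidence on the cause of these numbers is at hand.

The compounds shown do not tell how an unsubstituted phenyl, a furan-2-yl ring or a saturated amine such as morpholine would fare at this position. They also leave open whether a chlorine or a methyl group on the thiophene ring would move the number at all.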